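Swapping Benzyl for Pyridin-2-yl: An Estimate

This account rests on a few compounds, and the source may have more. Where it says the series, first, only, none or still open, it means among the compounds named here.

The measured compounds in an assay on isolated protein for inhibition of Myeloperoxidase (Homo sapiens), with a stated time of 10 min; on this read-out higher numbers stand for weaker inhibition and lower numbers for stronger inhibition:
compound 1, `Nc1cc(Cc2ccn(-c3ccc(F)cc3)n2)c2nn[nH]c2n1`, gives 53 nM
compound 2, `Nc1cc(Cc2ccn(Cc3cccc(Cc4ccccc4)c3)n2)c2nn[nH]c2n1`, gives 39 nM
compound 3, `Nc1cc(Cc2ccn(Cc3ccccc3)n2)c2nn[nH]c2n1`, gives 120 nM

Compound 3 stands highest of the three numbers in this assay, and both steps leading to it lie beyond the scatter: a 2.3-fold higher number from compound 1 to compound 3 (0.35 log units; beyond the scatter), and a 3.1-fold higher number from compound 2 to compound 3 (0.49 log units; beyond the scatter). Among the compounds with values here, compound 3 is thus the weakest inhibitor of the three so far.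

Compound 4, `Nc1cc(Cc2ccn(-c3ccccn3)n2)c2nn[nH]c2n1`, differs from compound 3 in one place: pyridin-2-yl in place of benzyl on an aromatic nitrogen. The step from compound 1 to compound 3 bears most on this change, since in compound 1 an aromatic ring also sits directly on the aromatic nitrogen, whereas compound 3 carries a benzyl there; that step was modest and raised the number. The step from compound 2 to compound 3 concerns a different place and says little here. Putting a directly attached aromatic ring back is therefore expected to lower the number by a modest amount, a 2.0-fold lower number from compound 3 to compound 4 (0.30 log units; within the scatter). Compound 4 is expected to give about 60 nM in this assay, with a likely range from 25 nM to 150 nM.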

Compound 4, half-maximal inhibitory concentration: 54 nM
The estimate for compound 4 lay 1.1-fold (0.05 log units) above the measured number; low and high end bracket the measured number.
By their numbers in this assay, from the lowest: compounds 2, 1 and 4 (each within the scatter of the next); then compound 3.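

Replacing benzyl with pyridin-2-yl on the aromatic nitrogen gives, in this assay, a 2.2-fold lower number from compound 3 to compound 4 (0.35 log units; beyond the scatter), so the lower number seen with a directly attached ring is not confined to 4-fluorophenyl. The two directly attached rings are not told apart by this read-out, with a 1.0-fold higher number from compound 1 to compound 4 (0.01 log units; within the scatter), even though pyridin-2-yl brings a ring nitrogen and a hydrogen-bond acceptor that the carbon-only ring of benzyl lacks. Nothing available gives a reason for these results.

On these data alone, it remains open whether an aromatic ring is needed on this nitrogen at all, since a plain methyl group or a small saturated ring such as cyclopropyl would test that directly. A chain ending in an amine or a carboxylic acid at the same place also lies outside the compounds shown.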